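One methyl-for-methoxy swap, seen twice

The source may report more compounds than this note shows. Statements on the series, on what has been measured and on what is new or still open speak of the compounds shown alone.

Of the compounds shown here, three have been tested in a functional assay on the whole organism for inhibition, with Brassica napus as the target, with a stated time of 72 h, tested at 10 mg/L; on this read-out higher numbers stand for more inhibition of growth at the one concentration tested and lower numbers for less inhibition of growth. Compound 1 `Cc1onc(-c2ccc(Cl)cc2Cl)c1C(=O)/N=c1/nc2nc(Cl)cc(C)n2s1` gives 20.1% in this assay. Compound 3 `COc1cc(Cl)nc2n/c(=N/C(=O)c3c(-c4ccc(Cl)cc4Cl)noc3C)sn12` gives 28.6%. Compound 2 `COc1cc(OC)nc(NC(=S)NC(=O)c2c(-c3ccc(Cl)cc3Cl)noc2C)n1` gives 35.2%; its number lies beyond the scatter above that of compound 1, while its number and that of compound 3 lie within the scatter of each other. How the core of compound 2 differs from the core of compound 3 is not broken down here.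

Compound 1 is obtained from compound 3 by one change, (methyl in place of methoxy on an aromatic carbon), and that step is a number 8.5 percentage points lower from compound 3 to compound 1 (within the scatter). Compound 4 `COc1cc(C)nc(NC(=S)NC(=O)c2c(-c3ccc(Cl)cc3Cl)noc2C)n1` has not yet been measured; it is obtained from compound 2 by the change (methyl in place of methoxy on an aromatic carbon). Among the measured compounds shown here, this is the same kind of change as the one from compound 3 to compound 1, but the surroundings are not the same: in compound 3 the ring is part of a fused or bridged system of two rings, ortho to a fused ring, meta to a chloro group and meta to a fused ring, whereas in compound 2 the carbon is meta to a large group and meta to a methoxy group.

Because the same kind of change gave a number 8.5 percentage points lower from compound 3 to compound 1 (within the scatter), the expected step for compound 4 is a number 7.2 percentage points lower from compound 2 to compound 4 (within the scatter), a small shift that stays within the scatter. Compound 4 is therefore estimated to give 28% in this assay, most likely between 15% and 40%.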

Compound 4, percent growth inhibition at one concentration: 15.7%
The estimate for compound 4 lay 12.3 percentage points above the measured number; low and high end bracket the measured number.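

Swapping a methoxy for a methyl on this aromatic carbon gives, in this assay, a number 19.5 percentage points lower from compound 2 to compound 4 (beyond the scatter) and turns the 4,6-dimethoxypyrimidin-2-yl group into a 4-methoxy-6-methylpyrimidin-2-yl group. Among the compounds shown here, this is the only one of the two steps that stands clear of the usual scatter on its own, so these two pairs do not establish a firm drop on both cores, and they give no fixed size that can be carried from one core to another, nor any reason for the change. The two steps point the same way, and their sizes cannot be told apart, which leaves a lower number as a reasonable but tentative expectation for this swap on the two cores shown: the same change on two cores in this assay, a number 8.5 percentage points lower (within the scatter) from compound 3 to compound 1 and a number 19.5 percentage points lower (beyond the scatter) from compound 2 to compound 4, 11 percentage points apart, within the scatter of two such steps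

At this place the compounds shown carry only a methoxy or a methyl, so it remains open how an amine, a hydroxyl group or a longer chain such as ethyl would behave there. From the compounds shown here alone, it is also open what replacing the remaining methoxy group of compound 4 with a second methyl would do, and whether the same swap would give a similar step on any other core.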